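A methoxyphenyl variant in a hydrazone thiazole series

A few compounds are considered here, and "the series" means these few. Any claim that something is new, unique, unknown or untested is made for them only; others in the source may bear on it.

Three compounds have been measured in a functional assay on HL-60 cells (Homo sapiens) for inhibition, read by MTT assay, with a stated time of 72 h; a lower number here means a stronger inhibitor, a higher number a weaker inhibitor:

compound 1, `O=[N+]([O-])c1ccc(-c2csc(N/N=C/c3ccc(C(F)(F)F)cc3)n2)cc1`, gives 11500 nM
compound 2, `O=[N+]([O-])c1cccc(-c2csc(N/N=C/c3ccc(C(F)(F)F)cc3)n2)c1`, gives 29300 nM
compound 3, `FC(F)(F)c1ccc(/C=N/Nc2nc(-c3ccc(Cl)cc3Cl)cs2)cc1`, gives 17800 nM

Compound 3 sits second highest of the three numbers, yet its nearest neighbour is compound 1 and its furthest is compound 2, and both gaps lie within the scatter, so no order among the three can be read. Compound 4, `COc1ccc(-c2csc(N/N=C/c3ccc(C(F)(F)F)cc3)n2)cc1`, differs from compound 3 by 4-methoxyphenyl in place of 2,4-dichlorophenyl on an aromatic carbon. Every measured step in this set concerns the same aromatic carbon of the shared core: a 1.5-fold higher number from compound 1 to compound 3 (0.19 log units; within the scatter) and a 1.6-fold lower number from compound 2 to compound 3 (0.22 log units; within the scatter) are both within the scatter, and only a 2.5-fold higher number from compound 1 to compound 2 (0.41 log units; beyond the scatter) reaches a modest size. An aryl swap at this place has therefore moved this assay little so far, and compound 4 is expected to behave alike, with a 1.2-fold lower number from compound 3 to compound 4 (0.07 log units; within the scatter) giving no step beyond the scatter. For compound 4 the estimated value in this assay is 15000 nM, in a range from 6000 nM to 40000 nM.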

Compound 4, half-maximal inhibitory concentration: 3670 nM
Compound 4: middle estimate off by 4.1-fold (0.61 log units), on the high side, and the stated range ends above it.
By their numbers in this assay, from the lowest: compound 4; then compounds 1, 3 and 2 (each within the scatter of the next, the first and the last beyond it).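

In this assay this aromatic carbon proves more responsive than the earlier aryl swaps suggested, since 4-methoxyphenyl gives a 4.9-fold lower number from compound 3 to compound 4 (0.69 log units; beyond the scatter) and an 8.0-fold lower number from compound 2 to compound 4 (0.90 log units; beyond the scatter). The closest comparison is methoxy in place of nitro on the same phenyl group, which gives a 3.1-fold lower number from compound 1 to compound 4 (0.50 log units; beyond the scatter) and leaves compound 4 as the strongest inhibitor of the four, its step to each of the others lying beyond the scatter. Nothing in the available data explains this shift.

The compounds shown leave open whether a hydroxy, ethoxy or dimethylamino group in place of methoxy would keep this stronger inhibition. They also leave open whether the step would hold if a chlorine or a nitrile replaced the trifluoromethyl group elsewhere on the shared core.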